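Aryl Variation on the Amide Nitrogen of a Pyridopyrimidine Carboxamide

The source may report more compounds than this note shows. Statements on the series, on what has been measured and on what is new or still open speak of the compounds shown alone.

Measured compounds:
compound 1, `CN(C)CCNC(=O)c1c(O)c2cccnc2n(-c2ccccc2)c1=O`, 22.6%
compound 2, `O=C(Nc1cccc(Cl)c1)c1c(O)c2cccnc2n(-c2ccccc2)c1=O`, 7.6%

The two compounds share one core and differ only in the group carried on the amide-type nitrogen. In a functional assay on the whole organism for inhibition, with Rattus norvegicus as the target, read by paw edema, at a dose of 100 mg/kg by the oral route (on this read-out higher numbers stand for more inhibition at the one dose given (going by the name of the read-out) and lower numbers for less inhibition), compound 1 gives 22.6%, and compound 2 gives 7.6%. For the measured compounds named here, the single measured step, a number 15 percentage points lower from compound 1 to compound 2 (beyond the scatter), is beyond the scatter and leaves compound 2 as the lower of the two numbers on this read-out.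

Compound 3, `COc1ccccc1NC(=O)c1c(O)c2cccnc2n(-c2ccccc2)c1=O`, has not been measured. Its difference from compound 2 is 2-methoxyphenyl in place of 3-chlorophenyl on an amide-type nitrogen. Going by the values given here, the only measured step exchanges a 2-(dimethylamino)ethyl chain for an aromatic ring, so no step among the measured compounds bears directly on an exchange of one aryl group for another on this nitrogen. That one step does show that a change at this position can shift the read-out in this assay by a modest amount, while giving no direction for the present change. Compound 3 is therefore expected to stay close to compound 2, with a step of a number 4.4 percentage points higher from compound 2 to compound 3 (within the scatter) that may well lie within the scatter. The estimate for compound 3 is 12%, in a range from 0% to 30%.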

Compound 3, a percentage reported as inhibition, in the whole organism at one dose (the size of the read-out at that dose, not a potency): 8.1%
Compound 3: the middle estimate sits 3.9 percentage points above what was measured, within the range that was stated.
By their numbers in this assay, from the lowest: compounds 2 and 3 (each within the scatter of the next); then compound 1.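

In this assay, for the compounds shown here, the exchange of 3-chlorophenyl for 2-methoxyphenyl on the amide-type nitrogen gives a number 0.5 percentage points higher from compound 2 to compound 3 (within the scatter), the first step between two aromatic rings at this position, and on this read-out the two compounds cannot be told apart. The replacement of the 2-(dimethylamino)ethyl chain by 2-methoxyphenyl gives a number 14.5 percentage points lower from compound 1 to compound 3 (beyond the scatter), so the earlier result with 3-chlorophenyl no longer stands alone: among these three compounds, both aromatic groups give a lower number than the chain, and none goes against this. Because this step changes the substituent and its place on the ring at once, it cannot show what either change does alone, and nothing available explains the numbers at this position.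

The compounds shown leave open how a plain phenyl, a 4-chlorophenyl or a 2-chlorophenyl group would read on this nitrogen, which would separate the substituent from its place on the ring. They also leave open whether a longer chain ending in a dimethylamine, or a chain ending in a carboxylic acid, would give a number different from that of compound 1.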